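Thiophene for Furan: Where Compound 4 Should Land

The source may hold more compounds than are shown below. What is called first, only, known or untested is meant among the compounds shown, and "the series" means these compounds.

Measured so far in a functional assay on MDA-MB-435 cells (Homo sapiens) for cytotoxicity, read by MTT assay, with a stated time of 72 h; a higher number here means a weaker inhibitor, a lower number a stronger inhibitor:
Compound 1 `N[C@H]1CC[C@H](Nc2c(C(=O)NCc3ccco3)nc(Br)c3cccnc23)CC1`, at a limit: > 10000 nM.
Compound 2 `NCCCNc1c(C(=O)NCc2ccc(F)cc2)nc(Br)c2cccnc12`: 5000 nM.
Compound 3 `O=C(NCc1ccc(F)cc1)c1nc(Br)c2cccnc2c1NCCO`, at a limit: > 20000 nM.

Compound 1 gives in this assay only a limit and no number, so it sits at the limit of > 10000 nM in this assay, at which 1 of the 3 values shown sits, rather than at a measured point; of the three values shown, it is one of two that are limits, the other being that of compound 3, which stands at the limit of > 20000 nM in this assay, at which 1 of the 3 values shown sits. Within the data shown here, the single computed step, an at least 4.0-fold higher number from compound 2 to compound 3 (0.60 log units; beyond the scatter), concerns an exchange on the chain and does not involve the group altered here.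

Compound 4 `N[C@H]1CC[C@H](Nc2c(C(=O)NCc3cccs3)nc(Br)c3cccnc23)CC1` differs from compound 1 by thiophen-2-yl in place of furan-2-yl on a saturated chain carbon bound to an amide-type nitrogen. Among the measured compounds shown here, no measured pair among the three compounds shares this exchange, so the data give no indication of a shift beyond the scatter in either direction. The step that the limit leaves unreadable from compound 1 to compound 4 is expected to be small. Compound 4 is therefore estimated at 15000 nM, with a range from 5000 nM to 50000 nM, most likely again reported only as a limit.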

Compound 4, half-maximal inhibitory concentration: 4100 nM
Estimate against measurement, compound 4: 3.7-fold (0.56 log units) above; the measured number lies below the stated range.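

In this assay, thiophen-2-yl in place of furan-2-yl on a saturated chain carbon bound to an amide-type nitrogen gives an at least 2.4-fold lower number from compound 1 to compound 4 (0.38 log units; beyond the scatter). This place on the molecule therefore responds to the exchange of one ring oxygen for sulfur, even though the two groups have the same count of heavy atoms, hydrogen-bond donors and hydrogen-bond acceptors. The true size of the step stays unknown because compound 1 is reported only as a limit: the limit of > 10000 nM in this assay, at which 1 of the 4 values shown sits.

From the compounds shown here alone, whether a phenyl or pyridin-2-yl ring in the same place would lower the number further remains open, as does the effect of a longer chain carrying the thiophen-2-yl. Going by these compounds, it is also open whether the same exchange would give a similar step on the 3-aminopropyl chain of compound 2.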